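Ester acyl variation: heptyl to cyclopropyl

The source may hold more compounds than are shown below. What is called first, only, known or untested is meant among the compounds shown, and "the series" means these compounds.

Compound 1 `Cc1cn([C@H]2CO[C@@H](COC(=O)C(C)(C)C)O2)c(=O)[nH]c1=O` and compound 2 `CCCCCCCC(=O)OC[C@@H]1OC[C@H](n2cc(C)c(=O)[nH]c2=O)O1` share the same core and differ only in the group attached to the ester carbonyl carbon. In a physicochemical assay for metabolic stability, at pH 8, in the presence of a further agent that is not named here (a higher number here means that the compound lasts longer, a lower number that the compound disappears faster), compound 1 gives 0.283 h, while compound 2 gives 0.483 h. For the measured compounds named here, the one measured step in the set is a 1.7-fold higher number from compound 1 to compound 2 (0.23 log units; within the scatter). Compound 2 therefore carries the higher of the two numbers in this assay, but its nearest neighbour, compound 1, sits within the scatter, so no order between the two can be claimed.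

Compound 3 `Cc1cn([C@H]2CO[C@@H](COC(=O)C3CC3)O2)c(=O)[nH]c1=O` is not yet measured. Its change from compound 2 is cyclopropyl in place of heptyl on a carbonyl carbon. Going by the values given here, the only step bearing on this position is a 1.7-fold higher number from compound 1 to compound 2 (0.23 log units; within the scatter), an exchange of one acyl group for another at the same carbonyl carbon that stayed within the scatter. With a single such step available and no sign of a direction in it, the exchange to cyclopropyl is expected to move the half-life no further than the scatter: a 1.4-fold lower number from compound 2 to compound 3 (0.14 log units; within the scatter). For compound 3 the estimate in this assay is 0.35 h, with a range from 0.15 h to 0.8 h.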

Compound 3, half-life: 0.288 h
Compound 3: middle estimate off by 1.2-fold (0.08 log units), on the high side, and the stated range covers the measured number.
By their numbers in this assay, from the lowest: compounds 1, 3 and 2 (each within the scatter of the next).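

With cyclopropyl on the carbonyl carbon, the series now holds three acyl groups at this position, and in this assay the exchange of heptyl for cyclopropyl gives a 1.7-fold lower number from compound 2 to compound 3 (0.22 log units; within the scatter) while the exchange of tert-butyl for cyclopropyl gives a 1.0-fold higher number from compound 1 to compound 3 (0.01 log units; within the scatter) and so every pair among compounds 1, 2 and 3 lies within the scatter. The set now spans an open chain of 7 carbon atoms, a branched tert-butyl group and a three-membered ring of 3 carbon atoms, yet neither the heavy-atom count nor the presence of a ring separates these compounds in half-life, and no order among them can be claimed. No measurement at hand bears on what governs the half-life at this position.

All three groups shown contain carbon only, so it remains open whether an acyl group carrying an amine or a carboxylic acid would give a half-life beyond the scatter of these values. As far as these compounds go, a phenyl ring or a much longer chain on the same carbonyl carbon is equally open, as is any change to the shared core.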